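A few compounds are considered here, and "the series" means these few. Any claim that something is new, unique, unknown or untested is made for them only; others in the source may bear on it.

Of the compounds shown here, three built on one shared core have been tested in a functional assay on the whole organism for inhibition, with Rattus norvegicus as the target, at a dose of 3 mg/kg by the oral route; a lower number here means a weaker effect, a higher number a stronger effect of the compound at the dose given. Compound 1 `CC(C)c1ccnc(C(=O)Nc2nn[nH]n2)c1` gives 34%, compound 2 `O=C(Nc1nn[nH]n1)c1cc(Br)ccn1` gives 34%, and compound 3 `CCCCOc1cccc(C(=O)Nc2nn[nH]n2)n1` gives 18%. Compound 3 stands lowest of the three measured values, with compound 1 and compound 2 each lying beyond the usual scatter above it. Compound 4 `O=C(Nc1nn[nH]n1)c1ccccn1` differs from compound 3 in a single place: hydrogen in place of butoxy on an aromatic carbon. Within the data shown here, the one measured step, no change at the digits printed from compound 1 to compound 2 (within the scatter), exchanged one group for another on a different carbon of the core and does not speak to taking a group away entirely. The compound carrying butoxy is the weakest of those measured, and the removal of that group has no measured parallel, leaving the direction open. Compound 4 is estimated to lie somewhere between the weak reading of compound 3 and the higher readings of the other two, with a wide range. The expected step is a number 10 percentage points higher from compound 3 to compound 4 (within the scatter). Compound 4 is estimated at 28%, with a range from 10% to 46%.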

Compound 4, a percentage reported as inhibition, in the whole organism at one dose (the size of the read-out at that dose, not a potency): 29%
Compound 4: middle estimate off by 1 percentage points, on the low side; measured number inside the range.
By their numbers in this assay, from the lowest: compound 3; then compounds 4, 1 and 2 (each within the scatter of the next).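

In this assay, replacing butoxy with hydrogen on the aromatic carbon next to the ring nitrogen gives a modest but real rise (a number 11 percentage points higher from compound 3 to compound 4 (beyond the scatter)), so butoxy at this position goes with a lower reading than no group at all. Neither of the other two groups can be told apart from hydrogen (a number 5 percentage points lower from compound 2 to compound 4 (within the scatter); a number 5 percentage points lower from compound 1 to compound 4 (within the scatter)), which means that compound 4 reaches the level of compound 1 and compound 2 without bromo or isopropyl. Nothing available explains why the loss of butoxy goes with this rise.

From the compounds shown here alone, it remains open whether a smaller group at the same carbon, such as methoxy or an amine, would read like hydrogen or like butoxy. Going by these compounds, it is also open whether these readings would hold at other oral doses.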